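The source may hold more compounds than are shown below. What is called first, only, known or untested is meant among the compounds shown, and "the series" means these compounds.

Working notes on a functional assay on A549 cells (Homo sapiens) for cytotoxicity, read by MTT assay, with a stated time of 72 h (a lower number here means a stronger inhibitor, a higher number a weaker inhibitor), for this series. Compound 1 `O=C(N/N=C/c1ccc([N+](=O)[O-])cc1)Nc1cc2c(Nc3ccc(F)c(Cl)c3)ncnc2cc1O[C@H]1CCOC1` gives 31200 nM and compound 2 `O=C(N/N=C/c1cccc(Cl)c1Cl)Nc1cc2c(Nc3ccc(F)c(Cl)c3)ncnc2cc1O[C@H]1CCOC1` gives 25000 nM while compound 3 `COc1ccc(/C=N/NC(=O)Nc2cc3c(Nc4ccc(F)c(Cl)c4)ncnc3cc2O[C@H]2CCOC2)cc1` gives 33100 nM on the same shared core. Compound 3 stands together with the other two, with a 1.1-fold higher number from compound 1 to compound 3 (0.03 log units; within the scatter) and a 1.3-fold higher number from compound 2 to compound 3 (0.12 log units; within the scatter) as its steps, and neither step separates it from them. Compound 4 `O=C(N/N=C/c1ccc(O)c(Br)c1)Nc1cc2c(Nc3ccc(F)c(Cl)c3)ncnc2cc1O[C@H]1CCOC1` carries 3-bromo-4-hydroxyphenyl in place of 4-methoxyphenyl on a carbon with a double bond to nitrogen. The difference 3-bromo-4-hydroxyphenyl in place of 4-methoxyphenyl on a carbon with a double bond to nitrogen falls at the same place as the measured swaps among 4-nitrophenyl, 2,3-dichlorophenyl and 4-methoxyphenyl. Those two steps and a 1.2-fold lower number from compound 1 to compound 2 (0.10 log units; within the scatter) all stay within the scatter, so no step beyond the scatter is expected in this assay for this change, in either direction. Among the measured compounds shown here, no measured compound carries 3-bromo-4-hydroxyphenyl, so the range is kept wide. The estimated step is a 1.3-fold lower number from compound 3 to compound 4 (0.10 log units; within the scatter) and lies within the scatter. For compound 4 the expected value is 26000 nM with an estimated range from 11000 nM to 50000 nM as its bounds.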

Compound 4, half-maximal inhibitory concentration: 4310 nM
Compound 4: the middle estimate sits 6.0-fold (0.78 log units) above what was measured; measured number below the stated range.
By their numbers in this assay, from the lowest: compound 4; then compounds 2, 1 and 3 (each within the scatter of the next).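

At this position, on a carbon with a double bond to nitrogen, the swaps among 4-nitrophenyl, 2,3-dichlorophenyl and 4-methoxyphenyl stayed within the scatter in this assay but 3-bromo-4-hydroxyphenyl brings steps beyond it (a 7.7-fold lower number from compound 3 to compound 4 (0.89 log units; beyond the scatter)) and (a 5.8-fold lower number from compound 2 to compound 4 (0.76 log units; beyond the scatter)) and (a 7.2-fold lower number from compound 1 to compound 4 (0.86 log units; beyond the scatter)). Among the compounds shown here, the position is therefore not indifferent to the group it carries, and compound 4 is the only one of the four compounds whose steps to all the others lie beyond the scatter. No measurement at hand accounts for this difference.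

As far as these compounds go, whether the step follows the bromine, the hydroxyl or the two together stays open, as 3-bromo-4-hydroxyphenyl brings both at once. Also open, from the compounds shown here alone, is how this assay would read a 4-hydroxyphenyl group without bromine or a 4-aminophenyl group at this place.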